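A few compounds are considered here, and "the series" means these few. Any claim that something is new, unique, unknown or untested is made for them only; others in the source may bear on it.

Compound 2 (`N#CC1=C(N)Oc2c(N)cc3nc4ccccc4nc3c2C12C(=O)N(Cc1cnnn1-c1cccc(C(F)(F)F)c1)c1ccccc12`) stands only at a limit in an ADME assay on HUVEC cells (Homo sapiens) for antiproliferative activity, read by MTT assay, with a stated time of 48 h; on this read-out lower numbers stand for stronger inhibition and higher numbers for weaker inhibition: in that assay compound 2 gives > 50000 nM, which is a limit of the assay rather than a number. Compound 1 (`N#CC1=C(N)Oc2c(c3nc4ccccc4nc3c3ccccc23)C12C(=O)N(Cc1cnnn1-c1ccc(F)c(Cl)c1)c1ccccc12`) gives > 50000 nM in this assay, likewise a limit. Thus (the limit of > 50000 nM in this assay, at which 2 of the 2 values shown sit), and no step between measured compounds can be drawn from these two values.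

Compound 3 (`CCc1cccc(C)c1-n1nncc1CN1C(=O)C2(C(C#N)=C(N)Oc3c(N)cc4nc5ccccc5nc4c32)c2ccccc21`) differs from compound 2 by 2-ethyl-6-methylphenyl in place of 3-(trifluoromethyl)phenyl on an aromatic nitrogen; in words, 2-ethyl-6-methylphenyl in place of 3-(trifluoromethyl)phenyl on an aromatic nitrogen.

Since both measured compounds sit at the limit, no step beyond the scatter is expected in this assay from this change; compound 3 is expected to remain at or near the limit. For compound 3 the estimated value in this assay is 60000 nM, within 20000 nM to 200000 nM. This estimate means an expected step that the limit leaves unreadable from compound 2 to compound 3.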

Compound 3, half-maximal inhibitory concentration: > 50000 nM
Compound 3: a limit, no number (the forecaster's own chance of this, stated with the estimate: 80%); the middle value does not contradict the limit.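

Compound 2 and compound 3 both stand at a limit in this assay rather than at a number, so no step between them can be read: the limit of > 50000 nM in this assay, at which 3 of the 3 values shown sit.

The compounds shown leave open whether 2-ethyl-6-methylphenyl in place of 3-(trifluoromethyl)phenyl changes the activity at all, and what actual value any of the three compounds has.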